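Swapping trifluoromethyl for nitro on a piperazine urea

A few compounds are considered here, and "the series" means these few. Any claim that something is new, unique, unknown or untested is made for them only; others in the source may bear on it.

Measured compounds:
- Compound 1 `Cc1ccc(NC(=O)N2CCN(c3ncccc3C(F)(F)F)CC2)cc1`: 556 nM
- Compound 2 `CC(C)c1ccc(NC(=O)N2CCN(c3ncccc3C=O)CC2)cc1`: 201 nM
- Compound 3 `O=C(Nc1ccc(C(F)(F)F)cc1)N1CCN(c2ncccc2Cl)CC1`: 63.5 nM

All three were tested in a functional assay on HEK293 cells for antagonist activity at transient receptor potential cation channel subfamily V member 1 (Rattus norvegicus); a lower number here means a stronger inhibitor, a higher number a weaker inhibitor. Compound 3 gives the lowest number of the three in this assay: its value lies beyond the scatter from compound 2 and further still from compound 1, so it is the most potent of the set.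

Compound 4 `O=C(Nc1ccc([N+](=O)[O-])cc1)N1CCN(c2ncccc2Cl)CC1` is the next compound and has not yet been measured. It differs from compound 3 in one place: nitro in place of trifluoromethyl on an aromatic carbon. Within the data shown here, no pair of measured compounds shows this exchange, so its effect cannot be read from the data.

The expected step of a 1.6-fold higher number from compound 3 to compound 4 (0.20 log units; within the scatter) is a small weakening that may not exceed the scatter. The estimate for compound 4 is 100 nM, within a range from 30 nM to 400 nM.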

Compound 4, half-maximal inhibitory concentration: 1110 nM
For compound 4 the middle estimate is 11-fold (1.05 log units) below the measured one; measured number above the stated range.
By their numbers in this assay, from the lowest: compound 3; then compound 2; then compounds 1 and 4 (each within the scatter of the next).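

The exchange of trifluoromethyl for nitro on this aromatic carbon is far from neutral: it gives a 17-fold higher number from compound 3 to compound 4 (1.24 log units; beyond the scatter) on an otherwise unchanged core. Among these compounds, this is the first pair here that differs in one place, and it shows that potency depends strongly on which group occupies this carbon. Nothing at hand accounts for the loss. From the compounds shown here alone, it remains open how a nitrile or an amine on the same carbon would compare with these two groups, and whether the exchange costs as much when chlorine elsewhere on the core is replaced.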